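A Propargyl Amide Replaces the Basic Side Chain

The compounds below may be only part of what the source reports. "The series", "measured", "known", "first", "only" and "open" are said of these compounds alone.

Three amides sharing one core have been measured in an assay on HL-60 cells for agonist activity at vitamin D3 receptor (Homo sapiens), read by microscopy, with a stated time of 96 h; on this read-out higher numbers stand for an effect only at larger amounts of compound and lower numbers for an effect already at smaller amounts. Compound 3 `CCn1c(C(=O)NCCN(C)C)ccc1C(CC)(CC)c1ccc(OCC(O)C(C)(C)C)c(C)c1` gives 14 nM, the lowest of the three numbers. Compound 1 `CC[C@@H](C)[C@H](NC(=O)c1ccc(C(CC)(CC)c2ccc(OCC(O)C(C)(C)C)c(C)c2)n1CC)C(=O)OC` gives 26 nM, and the difference from compound 1 to compound 3 is a 1.9-fold lower number from compound 1 to compound 3 (0.27 log units; within the scatter), so the two cannot be ranked. Compound 2 `CCN(CC)CCNC(=O)c1ccc(C(CC)(CC)c2ccc(OCC(O)C(C)(C)C)c(C)c2)n1CC` gives 110 nM, and the step of a 7.9-fold lower number from compound 2 to compound 3 (0.90 log units; beyond the scatter) shows that the amine substituents on this side chain do matter.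

Compound 4 `C#CCNC(=O)c1ccc(C(CC)(CC)c2ccc(OCC(O)C(C)(C)C)c(C)c2)n1CC` differs from compound 3 by ethynyl in place of (dimethylamino)methyl on a saturated chain carbon bound to an amide-type nitrogen. Going by the values given here, no measured step removes the amine outright; the nearest guide is the step from compound 2 to compound 3, which was a 7.9-fold lower number from compound 2 to compound 3 (0.90 log units; beyond the scatter) for a change at the same chain position, and the step of a 1.9-fold lower number from compound 1 to compound 3 (0.27 log units; within the scatter), which shows that a side chain without a basic amine can still give a similar number. Compound 4 is therefore expected to show a modest change of a 2.1-fold higher number from compound 3 to compound 4 (0.33 log units; beyond the scatter) in this assay, most likely toward a higher number. Compound 4 is estimated at 30 nM, with a range from 8 nM to 120 nM.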

Compound 4, half-maximal effective concentration: 240 nM
Compound 4: the middle estimate sits 8.0-fold (0.90 log units) below what was measured, outside the stated range (above it).
By their numbers in this assay, from the lowest: compounds 3 and 1 (each within the scatter of the next); then compound 2; then compound 4.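

In this assay, ethynyl in place of (dimethylamino)methyl gives a 17-fold higher number from compound 3 to compound 4 (1.23 log units; beyond the scatter) and is the only large step among these compounds, so this chain position responds more strongly to its substituent than the earlier compounds showed. Compound 4 also stands apart from the other two, with a 2.2-fold higher number from compound 2 to compound 4 (0.34 log units; beyond the scatter) and with a 9.2-fold higher number from compound 1 to compound 4 (0.97 log units; beyond the scatter) even though compound 1 has no amine in its side chain either, so the loss of the amine alone does not settle the number here. No measurement offered here explains this rise.

From the compounds shown here alone, it remains open whether the triple bond or the shorter chain goes with the higher number; a propyl group or a longer chain ending in ethynyl on the same nitrogen would separate the two. Also open, going by these compounds, is how a cyclic amine such as piperidine or a carboxylic acid at the end of the chain would read.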